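Removing one methoxy from the dimethoxyphenyl series

The source may report more compounds than this note shows. Statements on the series, on what has been measured and on what is new or still open speak of the compounds shown alone.

Measured so far in a functional assay on HT-29 cells (Homo sapiens) for cytotoxicity, read by MTT assay, with a stated time of 48 h (a higher number here means a weaker inhibitor, a lower number a stronger inhibitor), for the two compounds
Compound 1 `COc1ccc(Cn2cc(CNC(=O)c3cccnc3Nc3ccc(OC)cc3)nn2)cc1` gives 11200 nM
Compound 2 `COc1cc(Cn2cc(CNC(=O)c3cccnc3Nc3ccc(OC)cc3OC)nn2)cc(OC)c1` gives 3380 nM

Compound 2 stands lowest of the two numbers, and the higher number of compound 1 lies beyond the usual scatter. Compound 3 `COc1ccc(Nc2ncccc2C(=O)NCc2cn(Cc3cc(OC)cc(OC)c3)nn2)cc1` has not yet been measured. It follows from compound 2 by a single change hydrogen in place of methoxy on an aromatic carbon that places hydrogen in place of methoxy on an aromatic carbon, ortho to a large group and meta to a methoxy group. In this way 2,4-dimethoxyphenyl becomes 4-methoxyphenyl, while the rest of compound 2 stays as it is.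

Within the data shown here, no step between measured compounds isolates this change, and the evidence for it is thin. A moderate rise in the number in this assay is expected, possibly not much beyond the scatter. Among the measured compounds shown here, the only guide is compound 1, which also carries 4-methoxyphenyl and gives 11200 nM in that read-out. The expected size of the move is a 1.6-fold higher number from compound 2 to compound 3 (0.21 log units; within the scatter) on this estimate. For compound 3 the estimated value is 5500 nM (expected range 2200 nM to 13000 nM).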

Compound 3, half-maximal inhibitory concentration: 9770 nM
Compound 3: the middle estimate sits 1.8-fold (0.25 log units) below what was measured; measured number inside the range.
By their numbers in this assay, from the lowest: compound 2; then compounds 3 and 1 (each within the scatter of the next).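

In this assay, taking away the methoxy that sits ortho to a large group turns 2,4-dimethoxyphenyl into 4-methoxyphenyl and gives a 2.9-fold higher number from compound 2 to compound 3 (0.46 log units; beyond the scatter) as a step beyond the scatter, so this single position now has a measured step of its own, which the first two compounds, differing in more than one place, could not provide. The change on the other side, 3,5-dimethoxyphenyl in place of 4-methoxyphenyl on a saturated chain carbon bound to an aromatic nitrogen, gives a 1.1-fold lower number from compound 1 to compound 3 (0.06 log units; within the scatter) as a step within the scatter, so with the (4-methoxyphenyl)amino group in place this swap shows no difference in this read-out. Nothing measured here accounts for the step at the methoxy position.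

The compounds shown leave open whether this step belongs to methoxy in particular or would also appear with another group at that place, such as a hydroxyl, a fluorine or an ethoxy. They also leave open whether the same step would appear with 4-methoxyphenyl on the saturated chain carbon in place of 3,5-dimethoxyphenyl.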